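Adding Another Chloro to Compound 2

A few compounds are considered here, and "the series" means these few. Any claim that something is new, unique, unknown or untested is made for them only; others in the source may bear on it.

For the measured compounds named here, compound 2 `O=c1oc2ccccc2cc1C1=NN(c2ccccc2)[C@@H](c2ccc(Cl)cc2)C1` gives 39.2% in a functional assay on the whole organism (strain albino) for inhibition, with Rattus norvegicus as the target, read by paw edema, with stated times of 1 h and 2 h, at a dose of 200 mg/kg by the oral route (a lower number here means less inhibition, a higher number more inhibition at the dose given (going by the name of the read-out)), the highest of the two numbers measured so far. Going by the values given here, compound 1 `COc1ccc([C@H]2CC(c3cc4ccccc4oc3=O)=NN2c2ccccc2)cc1` gives 24.8%, and the step of a number 14.4 percentage points higher from compound 1 to compound 2 (beyond the scatter) is the only measured step. Compound 3 `O=c1oc2ccccc2cc1C1=NN(c2ccccc2)[C@@H](c2ccc(Cl)cc2Cl)C1` differs from compound 2 by chloro in place of hydrogen on an aromatic carbon. Among the compounds with values here, no measured step tracks a chloro entering where a hydrogen leaves; the one step that bears on it, a number 14.4 percentage points higher from compound 1 to compound 2 (beyond the scatter), shows a chloro entering on an aromatic carbon moving the number up modestly. The expected step, a number 5.8 percentage points higher from compound 2 to compound 3 (within the scatter), is a modest rise or none beyond the scatter. Compound 3 is estimated at 45%, within 30% to 58%.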

Compound 3, a percentage reported as inhibition, in the whole organism at one dose (the size of the read-out at that dose, not a potency): 56.7%
Estimate against measurement, compound 3: 11.7 percentage points below; the range from low to high includes it.
By their numbers in this assay, from the lowest: compound 1; then compound 2; then compound 3.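

The step to 2,4-dichlorophenyl is a number 17.5 percentage points higher from compound 2 to compound 3 (beyond the scatter) in this assay, so a chloro can replace hydrogen on this aromatic carbon, ortho to a large group and meta to a chloro group, with the number rising. Replacing 4-methoxyphenyl with 2,4-dichlorophenyl gives a number 31.9 percentage points higher from compound 1 to compound 3 (beyond the scatter) and is a large change. No evidence on the reason for either rise is available.

As far as these compounds go, whether fluoro, a methyl group or an amine on this carbon would do the same remains open. So does whether the second chloro would raise the number on another carbon of this ring.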